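A few compounds are considered here, and "the series" means these few. Any claim that something is new, unique, unknown or untested is made for them only; others in the source may bear on it.

In an assay on isolated protein for binding affinity to 5-hydroxytryptamine receptor 1D (Homo sapiens) (a higher number here means a weaker inhibitor, a lower number a stronger inhibitor), the measured compounds gave these values.
Compound 1 `Clc1ccc(-c2n[nH]cc2N2CCCNCC2)cc1`: 1230 nM.
Compound 2 `Fc1ccc(-c2n[nH]cc2N2CCCNCC2)cc1`: 2190 nM.
Compound 3 `Clc1cccc(-c2n[nH]cc2N2CCNCC2)c1`: only a limit, > 10000 nM.

Compound 1 and compound 2 share a core and differ in one place, (fluoro in place of chloro on an aromatic carbon); that change brought a 1.8-fold higher number from compound 1 to compound 2 (0.25 log units; within the scatter). How the core of compound 3 differs from the core of compound 1 is not broken down here. Compound 4 `Fc1cccc(-c2n[nH]cc2N2CCNCC2)c1` is not yet measured and differs from compound 3 by fluoro in place of chloro on an aromatic carbon. This is the same kind of change as that from compound 1 to compound 2, but the place is not the same: there the fluoro stands para to a large group, here meta to a large group. The value of compound 3 is a limit, (the limit of > 10000 nM in this assay, at which 1 of the 3 values shown sits). The step from compound 3 to compound 4 is expected to be a step that the limit leaves unreadable from compound 3 to compound 4, which rests on a 1.8-fold higher number from compound 1 to compound 2 (0.25 log units; within the scatter) and on compound 3 sitting at a limit. For compound 4 the expected value is 15000 nM, most likely between 4000 nM and 60000 nM.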

Compound 4, inhibition constant: 911 nM
For compound 4 the middle estimate is 16-fold (1.22 log units) above the measured one; the measured number lies below the stated range.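

In this assay, putting fluoro in place of chloro on an aromatic carbon gave an at least 10-fold lower number from compound 3 to compound 4 (1.04 log units; beyond the scatter), and this differs from the earlier step on the other core: the same change on two cores in this assay, a 1.8-fold higher number (0.25 log units; within the scatter) from compound 1 to compound 2 and an at least 10-fold lower number (1.04 log units; beyond the scatter) from compound 3 to compound 4, at least 19-fold (1.29 log units) apart, beyond the scatter of two such steps. As far as these compounds go, compound 3 stands at a limit and not at a number, so the exact size of the new step stays unknown: the limit of > 10000 nM in this assay, at which 1 of the 4 values shown sits. The effect of this change therefore cannot simply be carried from one core to another in this series, but these compounds do not show whether the core or the place of the halogen on the aromatic ring accounts for the difference.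

From the compounds shown here alone, it remains open how other groups at this place, such as methyl or methoxy, would behave on either core.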